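Swapping Fluoro for Trifluoromethyl in Compound 2

The source may hold more compounds than are shown below. What is called first, only, known or untested is meant among the compounds shown, and "the series" means these compounds.

Of the compounds shown here, three have been tested so far in a functional assay on HepG2 cells (Homo sapiens) for antiproliferative activity, read by MTT assay, with a stated time of 24 h (a higher number here means a weaker inhibitor, a lower number a stronger inhibitor), and only one of them gives an exact number. Compound 1 (`C=CCc1ccc(OCC(=O)OCC)c(-c2ccc(OCC(=O)OCC)c(CC=C)c2)c1`) gives 68900 nM. Compound 3 (`C=CCc1ccc(OCC)c(-c2ccc(OCC)c(CC=C)c2)c1`) gives > 124000 nM, which is a limit and not a number. Compound 2 (`C=CCc1cc(-c2ccc(F)cc2)ccc1O`) gives > 100000 nM, which is also a limit. Compound 2 therefore has no exact place on the scale of this assay, and any comparison with it has to start from that limit.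

The next compound to be tested is compound 4 (`C=CCc1cc(-c2ccc(C(F)(F)F)cc2)ccc1O`). It has trifluoromethyl in place of fluoro on an aromatic carbon, para to a large group: trifluoromethyl in place of fluoro on an aromatic carbon. Going by the values given here, no two measured compounds here differ in only one place, so the data do not show directly what this swap does. The expectation therefore rests on compound 2 and its limit of > 100000 nM. The expected change is no larger than the usual scatter, with only a slight lean towards a stronger inhibitor: an at least 1.1-fold lower number from compound 2 to compound 4 (0.04 log units; that floor lies within the scatter). It is also quite possible that the test again returns only a limit. The estimated value for compound 4 is 90000 nM, with an expected range from 35000 nM to 160000 nM.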

Compound 4, half-maximal inhibitory concentration: 60300 nM
Beside the measured number, compound 4's estimate is 1.5-fold (0.17 log units) above it, and the stated range covers the measured number.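

Going by these compounds alone, the swap of trifluoromethyl for fluoro on an aromatic carbon, para to a large group, gives an at least 1.6-fold lower number from compound 2 to compound 4 (0.21 log units; that floor lies within the scatter) in this assay, and this is the first direct reading of a change at a single place in this set. It also puts an exact number on a compound of this kind, so later changes at this position have a firm point to be compared with, which the limit alone could not offer. On these data alone, the printed floor lies within the scatter, yet it is only a floor, and the real size of the step stays unknown because compound 2 has a limit and not a number: the limit of > 100000 nM in this assay, at which 1 of the 4 values shown sits.

Among the compounds shown, this position carries only fluoro and trifluoromethyl, so one step cannot show whether the trend would hold for other groups or whether it is a real trend at all. A chlorine atom, a methoxy group, a nitrile or an amine at the same place would show how far the number in this assay can move from that of compound 4.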